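Trimming the Amide Aryl Group: What Compound 3 Might Give

This account rests on a few compounds, and the source may have more. Where it says the series, first, only, none or still open, it means among the compounds named here.

Compound 1 `COc1cc(-c2nn(-c3cccc(NC(=O)c4cccc(C(F)(F)F)c4)c3)cc2-c2ccncc2)ccc1Cl`: 710 nM in a functional assay on MDA-MB-435 cells (Homo sapiens) for inhibition, read by sulforhodamine B assay, with a stated time of 48 h; a lower number here means a stronger inhibitor, a higher number a weaker inhibitor
Compound 2 `COc1cc(-c2nn(-c3cccc(NC(=O)c4ccc(Cl)c(C(F)(F)F)c4)c3)cc2-c2ccncc2)ccc1Cl`: 660 nM in this assay

In this assay compound 2 stands beside compound 1 at a number within the scatter of it, since a 1.1-fold lower number from compound 1 to compound 2 (0.03 log units; within the scatter). Compound 3 `COc1cc(-c2nn(-c3cccc(NC(=O)c4ccccc4)c3)cc2-c2ccncc2)ccc1Cl` differs from compound 2 by phenyl in place of 4-chloro-3-(trifluoromethyl)phenyl on a carbonyl carbon. Among the measured compounds shown here, only one measured step bears on this, a 1.1-fold lower number from compound 1 to compound 2 (0.03 log units; within the scatter), which removed the chloro alone; no measured step removes the trifluoromethyl. Compound 3 is therefore expected to give a modestly higher number, an estimated 1.8-fold higher number from compound 2 to compound 3 (0.26 log units; within the scatter). The estimate for compound 3 is 1200 nM, with a range from 500 nM to 3000 nM.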

Compound 3, half-maximal inhibitory concentration: 190 nM
For compound 3 the middle estimate is 6.3-fold (0.80 log units) above the measured one, and the stated range ends above it.
By their numbers in this assay, from the lowest: compound 3; then compounds 2 and 1 (each within the scatter of the next).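

In this assay, among the compounds shown here, trimming the amide aryl group to plain phenyl gives the first change at this position that lies beyond the scatter: a 3.5-fold lower number from compound 2 to compound 3 (0.54 log units; beyond the scatter), and a 3.7-fold lower number from compound 1 to compound 3 (0.57 log units; beyond the scatter). The chloro step had shown no such change, and compound 3, with no substituent on this ring, now has the lowest number of the three. No evidence is available to explain this difference. The compounds shown leave open whether a single methoxy or amine on this phenyl would keep the lower number, and how a simple alkyl chain in place of the phenyl would fare.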